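The compounds below may be only part of what the source reports. "The series", "measured", "known", "first", "only" and "open" are said of these compounds alone.

For the measured compounds named here, in a functional assay on Jurkat cells (Homo sapiens) for inhibition, read by CCK-8 assay, with a stated time of 48 h (a higher number here means a weaker inhibitor of growth, a lower number a stronger inhibitor of growth), only one of three measured compounds gives a true number: compound 2 `COc1ccccc1CNc1nc(Nc2ccc(N3CCN(C)CC3)cn2)ncc1Cl` reads 10800 nM. Compound 1 `CN1CCN(c2ccc(Nc3ncc(Cl)c(Nc4ccccc4)n3)nc2)CC1` reads > 100000 nM, which is a limit and not a number. Compound 3 `CN1CCN(c2ccc(Nc3ncc(Cl)c(NCc4ccco4)n3)nc2)CC1` reads > 100000 nM, which is also only a limit, so it stands at the limit of > 100000 nM in this assay, at which 2 of the 3 values shown sit.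

Compound 4 `CC(C)c1ccc(Nc2nc(Nc3ccc(N4CCN(C)CC4)cn3)ncc2Cl)cc1` differs from compound 3 by 4-isopropylphenyl in place of (furan-2-yl)methyl on a nitrogen on an aromatic ring, with 4-isopropylphenyl in place of (furan-2-yl)methyl on a nitrogen on an aromatic ring. The measured steps at that nitrogen show that the group there can matter. They are an at least 9.2-fold lower number from compound 1 to compound 2 (0.96 log units; beyond the scatter) and an at least 9.2-fold higher number from compound 2 to compound 3 (0.96 log units; beyond the scatter), while a step that the two limits leave unreadable from compound 1 to compound 3. None of these steps introduces 4-isopropylphenyl, so they guide the estimate only loosely. Compound 2, at 10800 nM, suggests how far a change at that nitrogen might reach, so a modest move toward a lower number is expected. Compound 4 could, however, also stay at the limit. The expected change is an at least 3.3-fold lower number from compound 3 to compound 4 (0.52 log units; beyond the scatter). Compound 4 is estimated at 30000 nM, with an expected range from 7000 nM to 100000 nM.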

Compound 4, concentration for 50% growth inhibition: 7530 nM
Compound 4: middle estimate off by 4.0-fold (0.60 log units), on the high side; low and high end bracket the measured number.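

Adding a single isopropyl to the plain phenyl ring gives an at least 13-fold lower number from compound 1 to compound 4 (1.12 log units; beyond the scatter), so a ring bound directly to this nitrogen does not by itself rule out growth inhibition, which the earlier compounds could not show. Putting 4-isopropylphenyl in place of (furan-2-yl)methyl gives an at least 13-fold lower number from compound 3 to compound 4 (1.12 log units; beyond the scatter), and both this step and the one before it are minimum sizes: the limit of > 100000 nM in this assay, at which 2 of the 4 values shown sit. The 2-methoxybenzyl and 4-isopropylphenyl groups cannot be told apart here, with a 1.4-fold lower number from compound 2 to compound 4 (0.16 log units; within the scatter), so a direct aromatic ring and a benzyl group can both reach this level.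

Going by these compounds, it remains open whether the isopropyl group is specifically needed, or whether a tert-butyl group or a carboxylic acid in its place would read the same. The compounds shown also leave open what a longer chain between this nitrogen and the ring would do.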